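Compound 2 to compound 4: relocating the fluorine

The source may report more compounds than this note shows. Statements on the series, on what has been measured and on what is new or still open speak of the compounds shown alone.

In a functional assay on HL-60 cells (Homo sapiens) for inhibition, read by MTT assay, with a stated time of 72 h (on this read-out higher numbers stand for weaker inhibition and lower numbers for stronger inhibition), three compounds carrying the 2-fluorophenyl group have been measured: compound 1 `Cc1nc(-c2ccccc2F)c(C(=O)N2CCN(c3cc(Cl)ccc3C)CC2)o1` gives 229 nM, compound 2 `COc1cccc(N2CCN(C(=O)c3oc(C)nc3-c3ccccc3F)CC2)c1` gives 56.1 nM and compound 3 `Cc1ccc(C)c(N2CCN(C(=O)c3oc(C)nc3-c3ccccc3F)CC2)c1` gives 319 nM. Compound 2 has the lowest number of the three, and its steps to both others lie beyond the scatter.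

The unmeasured compound 4 `COc1cccc(N2CCN(C(=O)c3oc(C)nc3-c3ccc(F)cc3)CC2)c1` differs from compound 2 in one group: 4-fluorophenyl in place of 2-fluorophenyl on an aromatic carbon. It has 4-fluorophenyl in place of 2-fluorophenyl on an aromatic carbon, and the rest of the structure is unchanged.

Among the compounds with values here, no measured step touches this group. All three change only the aryl group on the amine nitrogen in a ring: a 4.1-fold lower number from compound 1 to compound 2 (0.61 log units; beyond the scatter) and a 5.7-fold higher number from compound 2 to compound 3 (0.75 log units; beyond the scatter) are modest, while a 1.4-fold higher number from compound 1 to compound 3 (0.14 log units; within the scatter) is within the scatter. These steps show only how far the numbers in this small set have moved for a change elsewhere in the structure. They give no direction for the fluorine move. With compound 2 the lowest of three, a slight lean towards a higher number is assumed, and a modest size is the working expectation.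

The expected change is a 1.7-fold higher number from compound 2 to compound 4 (0.23 log units; within the scatter). For compound 4 the estimated value is 95 nM, with an expected range of 28 nM to 320 nM.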

Compound 4, half-maximal inhibitory concentration: 112 nM
Estimate against measurement, compound 4: 1.2-fold (0.07 log units) below; low and high end bracket the measured number.
By their numbers in this assay, from the lowest: compounds 2 and 4 (each within the scatter of the next); then compounds 1 and 3 (each within the scatter of the next).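

In this assay, within the data shown here, the move of the fluorine gives a 2.0-fold higher number from compound 2 to compound 4 (0.30 log units; within the scatter), the first reading at this position: on an aromatic carbon of the five-membered aromatic ring with 1 nitrogen and 1 oxygen, next to the ring nitrogen. With the 3-methoxyphenyl group held on the amine nitrogen, this step lies within the scatter, so the 2-fluorophenyl and 4-fluorophenyl groups cannot be told apart here, and the low number of compound 2 is not tied to the 2-fluorophenyl group alone. No evidence at hand bears on why the two compounds read as they do.

The compounds shown leave open whether the same holds when the amine nitrogen carries the 5-chloro-2-methylphenyl or 2,5-dimethylphenyl group, since the fluorine move is seen only with the 3-methoxyphenyl group. They also leave open how far this position accepts other change, such as an unsubstituted phenyl, a 3-fluorophenyl, a 4-methoxyphenyl or a pyridine ring in place of the fluorophenyl group.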